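This account rests on a few compounds, and the source may have more. Where it says the series, first, only, none or still open, it means among the compounds named here.

Compound 1 `CN1CCN(C/C=C/C(=O)Nc2cc3c(N4CCc5ccccc54)ncnc3cc2O[C@@H]2CCOC2)CC1`, 6090 nM; compound 2 `O=C(/C=C/CN1CCC(CO)CC1)Nc1cc2c(N3CCc4ccccc43)ncnc2cc1O[C@@H]1CCOC1`, 3670 nM; compound 3 `COc1cc2ncnc(N3CCCc4ccccc43)c2cc1NC(=O)/C=C/CN1CCN(C)CC1`, 7830 nM.

These three compounds were tested in a functional assay on A549 cells (Homo sapiens) for antiproliferative activity, read by MTT assay, with a stated time of 72 h; a higher number here means a weaker inhibitor, a lower number a stronger inhibitor. Compound 4 `COc1cc2ncnc(N3CCCc4ccccc43)c2cc1NC(=O)/C=C/CN1CCC(CO)CC1` has not yet been measured in this assay. Compound 4 differs from compound 3 in one place: 4-(hydroxymethyl)piperidin-1-yl in place of 4-methylpiperazin-1-yl on a saturated chain carbon bound to a double-bonded chain carbon. The same change separates compound 2 from compound 1: 4-(hydroxymethyl)piperidin-1-yl in place of 4-methylpiperazin-1-yl on a saturated chain carbon bound to a double-bonded chain carbon. In that measured pair the step was a 1.7-fold lower number from compound 1 to compound 2 (0.22 log units; within the scatter). How the core of compound 3 differs from the core of compound 1 is not broken down here. As the place of the change is the same in both pairs, a step of similar size is expected for compound 4, namely a 1.7-fold lower number from compound 3 to compound 4 (0.23 log units; within the scatter), resting on the step seen from compound 1 to compound 2. Compound 4 is therefore estimated at 4600 nM in this assay, with a likely range from 2500 nM to 8500 nM.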

Compound 4, half-maximal inhibitory concentration: 6970 nM
Beside the measured number, compound 4's estimate is 1.5-fold (0.18 log units) below it; the range from low to high includes it.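

In this assay, putting 4-(hydroxymethyl)piperidin-1-yl in place of 4-methylpiperazin-1-yl gives a 1.1-fold lower number from compound 3 to compound 4 (0.05 log units; within the scatter). Set beside the earlier pair, the two steps do not differ: the same change on two cores in this assay, a 1.7-fold lower number (0.22 log units; within the scatter) from compound 1 to compound 2 and a 1.1-fold lower number (0.05 log units; within the scatter) from compound 3 to compound 4, 1.5-fold (0.17 log units) apart, within the scatter of two such steps. The change therefore behaves alike on these two cores, but as both steps lie within the scatter, this does not show that it has a real effect on either core, and two pairs cannot show that it would carry to further cores.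

The compounds shown leave open whether another group in the same place, such as morpholin-4-yl or dimethylamino, would shift the number beyond the scatter. They also leave open what a longer chain would do.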